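The source may hold more compounds than are shown below. What is called first, only, known or untested is meant among the compounds shown, and "the series" means these compounds.

Three compounds carrying the shared core of compound 1 `Cc1nc(C#Cc2cccc(C(F)(F)F)c2)cs1` have been tested in a functional assay on CHO cells for agonist activity at metabotropic glutamate receptor 5 (Homo sapiens), read by inositol phosphate accumulation; a higher number here means a weaker inhibitor, a lower number a stronger inhibitor. Compound 1 gives 413 nM in this assay, the lowest of the two numbers recorded. Compound 2 `Cc1nc(C#Cc2cnccn2)cs1` gives 1830 nM in this assay, a higher number that lies beyond the scatter of the measurement. Compound 3 `Cc1nc(C#Cc2ccc3[nH]ccc3c2)cs1` reaches only > 10000 nM in this assay, which is a limit of the measurement and not a number (the limit of > 10000 nM in this assay, at which 1 of the 3 values shown sits).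

The next compound, compound 4 `Cc1nc(C#Cc2cccc(C(N)=O)c2)cs1`, differs from compound 1 in one place: carbamoyl in place of trifluoromethyl on an aromatic carbon. Within the data shown here, no measured pair in this set covers such a change, so the expectation rests on the spread of the values alone, where compound 1 stands at the low end and the other two compounds are markedly weaker. For compound 4 the step from compound 1 is expected to be a 12-fold higher number from compound 1 to compound 4 (1.08 log units; beyond the scatter), a rise well beyond the scatter. The estimate for compound 4 in this assay is therefore 5000 nM, with a range from 1500 nM to 20000 nM.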

Compound 4, half-maximal inhibitory concentration: 1000 nM
Compound 4: middle estimate off by 5.0-fold (0.70 log units), on the high side; measured number outside the range, below it.
By their numbers in this assay, from the lowest: compound 1; then compounds 4 and 2 (each within the scatter of the next). At a limit, above all of these: compound 3.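

In this assay, the change at this aromatic carbon gives a 2.4-fold higher number from compound 1 to compound 4 (0.38 log units; beyond the scatter), a modest step. So this place does not depend on trifluoromethyl: carbamoyl, which brings a hydrogen-bond donor and a hydrogen-bond acceptor where trifluoromethyl has neither, costs some activity but does not abolish it. Nothing measured here explains the size of this step.

With a single replacement at this place, the compounds shown cannot separate the part played by the donor from that of the acceptor, or say how much of the step belongs to either. A nitrile, a carboxylic acid or an amine on the same carbon would show whether the activity seen with carbamoyl extends to other groups or is particular to it.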